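A few compounds are considered here, and "the series" means these few. Any claim that something is new, unique, unknown or untested is made for them only; others in the source may bear on it.

Measured so far in a functional assay on MCF7 cells (Homo sapiens) for cytotoxicity, read by sulforhodamine B assay, with a stated time of 48 h; a lower number here means that less compound is tolerated, a higher number that more compound is tolerated:
compound 1 `COc1cc(/C(Cl)=C/C=C(\C#N)C(=O)c2c[nH]c3ccccc23)cc(OC)c1OC` gives > 100000 nM
compound 2 `N#C/C(=C\C=C(/Cl)c1ccc(Br)cc1)C(=O)c1c[nH]c2ccccc12` gives > 100000 nM
compound 3 `COc1cc(/C(Cl)=C/C=C(\C#N)C(=O)c2c(C)[nH]c3ccccc23)cc(OC)c1OC` gives > 100000 nM

Each of these three values is a limit of this assay, not a number. For compound 1 the value > 100000 nM is such a limit. For compound 2 the value > 100000 nM is such a limit. For compound 3 the value > 100000 nM is such a limit.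

Compounds 1 and 3 share a core and differ by methyl in place of hydrogen on an aromatic carbon. The step that the two limits leave unreadable from compound 1 to compound 3 cannot be read because both values sit at the limit of > 100000 nM in this assay, at which 3 of the 3 values shown sit. Compound 2 differs from compound 1 in more than one place; the difference between the two cores is not broken down here.

Compound 4 `Cc1[nH]c2ccccc2c1C(=O)/C(C#N)=C/C=C(\Cl)c1ccc(Br)cc1` is not yet measured in this assay . It differs from compound 2 by methyl in place of hydrogen on an aromatic carbon, the same change as that from compound 1 to compound 3, described at the same place in the same words. Since the matching change gave a step that the two limits leave unreadable from compound 1 to compound 3 and all three values sit at the limit of > 100000 nM in this assay, at which 3 of the 3 values shown sit, compound 4 is expected to remain at the limit, and the expected step is a step that the limit leaves unreadable from compound 2 to compound 4. For compound 4 the estimate is 150000 nM, expected between 50000 nM and 400000 nM.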

Compound 4, concentration lethal to 50% of the cells: > 100000 nM
Compound 4 ended at the assay's limit (the forecaster's own chance of this, stated with the estimate: 85%); the middle value is on the limit's open side.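

In this assay compound 4 gives > 100000 nM, which is a limit of the assay and not a number. Among these compounds, no step from compound 2 to compound 4 can be read, because both values are limits: the limit of > 100000 nM in this assay, at which 4 of the 4 values shown sit. The compounds shown leave open whether methyl in place of hydrogen on an aromatic carbon changes the read-out at all.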